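The source may report more compounds than this note shows. Statements on the series, on what has been measured and on what is new or still open speak of the compounds shown alone.

Compound 1 `C=CCN(CCC)Cc1c(C(F)(F)F)nc2n(-c3c(C)cc(C)cc3C)c(Cl)cn12` gives 4.5 nM in an assay on cells for displacement of a labelled ligand from corticotropin-releasing factor receptor 1 (Homo sapiens), with a stated time of 100 min; on this read-out higher numbers stand for weaker inhibition and lower numbers for stronger inhibition.
Compound 2 `CCCN(Cc1c(C(F)(F)F)nc2n(-c3c(C)cc(C)cc3C)c(Cl)cn12)CC1CCC1` gives 5.3 nM.
Compound 3 `CCCN(Cc1ccc(Cl)cc1)Cc1c(C(F)(F)F)nc2n(-c3c(C)cc(C)cc3C)c(Cl)cn12` gives 28 nM.

Compound 3 stands highest of the three numbers in this assay, which makes it the weakest binder among them: a 6.2-fold higher number from compound 1 to compound 3 (0.79 log units; beyond the scatter) and a 5.3-fold higher number from compound 2 to compound 3 (0.72 log units; beyond the scatter), both beyond the usual scatter, whereas a 1.2-fold higher number from compound 1 to compound 2 (0.07 log units; within the scatter).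

Compound 4 `CCCN(Cc1ccc(F)cc1)Cc1c(C(F)(F)F)nc2n(-c3c(C)cc(C)cc3C)c(Cl)cn12` differs from compound 3 in a single place: fluoro in place of chloro on an aromatic carbon. For the measured compounds named here, none of the measured steps swaps one halogen for another on that ring. The two steps that lead to compound 3 exchange the whole 4-chlorophenyl group for vinyl or for cyclobutyl, so they speak to the presence of the aromatic ring itself rather than to what sits on it. With nothing closer to draw on, the swap of chloro for fluoro is expected to move the number in this assay by no more than the usual scatter, in either direction. Compound 4 is therefore expected to give about 30 nM, within a range from 12 nM to 75 nM, which amounts to an expected 1.1-fold higher number from compound 3 to compound 4 (0.03 log units; within the scatter).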

Compound 4, inhibition constant: 350 nM
Compound 4: middle estimate off by 12-fold (1.07 log units), on the low side, and the stated range ends below it.
By their numbers in this assay, from the lowest: compounds 1 and 2 (each within the scatter of the next); then compound 3; then compound 4.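

In this assay a single halogen on the aromatic ring proves to matter a great deal: fluoro in place of chloro gives a 13-fold higher number from compound 3 to compound 4 (1.10 log units; beyond the scatter), so what sits on the ring counts, and not only the presence of the ring. Putting 4-fluorophenyl in place of cyclobutyl gives a 66-fold higher number from compound 2 to compound 4 (1.82 log units; beyond the scatter) and putting it in place of vinyl gives a 78-fold higher number from compound 1 to compound 4 (1.89 log units; beyond the scatter), so the modest steps seen with 4-chlorophenyl do not hold for every aromatic group at this place. Nothing available explains the gap between chloro and fluoro here.

A bromo or methoxy group in the same place, or a bare phenyl ring, would show whether chloro or fluoro is the unusual case. On these data alone, whether the same swap would matter as much elsewhere on the ring also stays open.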